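The source may report more compounds than this note shows. Statements on the series, on what has been measured and on what is new or still open speak of the compounds shown alone.

Measured so far:
compound 1, `CC(C)Cc1ccc(C(C)C2=NNC(S)N2N)cc1`: 56%
compound 2, `CC(C)Cc1ccc(C(C)c2nnc(S)n2/N=C/c2ccc(Cl)cc2)cc1`: 64%

In a functional assay on the whole organism (strain Wistar albino) for inhibition, with Rattus norvegicus as the target, read by paw edema, with stated times of 30 min and 3 h, at a dose of 20 mg/kg by the oral route (a higher number here means more inhibition at the dose given (going by the name of the read-out), a lower number less inhibition), compound 2 gives 64%, the larger of the two numbers recorded, but its nearest neighbour, compound 1, gives 56%, and the gap between the two lies within the scatter of the read-out, so the pair is not told apart.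

Compound 3, `CC(C)Cc1ccc(C(C)c2nnc(S)n2/N=C/c2ccc(Br)cc2)cc1`, is the next to be measured in this assay. It differs from compound 2 by bromo in place of chloro on an aromatic carbon.

Within the data shown here, no pair of measured compounds shows this kind of change, so the data give no size for the step. The expectation is a step of no size beyond the scatter in either direction, no change at the digits printed from compound 2 to compound 3 (within the scatter), because compound 2 sits at 64% and nothing recorded argues for a move from there. Compound 3 is therefore estimated at 64%, with a range from 50% to 76%.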

Compound 3, a percentage reported as inhibition, in the whole organism at one dose (the size of the read-out at that dose, not a potency): 72%
For compound 3 the middle estimate is 8 percentage points below the measured one, within the range that was stated.
By their numbers in this assay, from the lowest: compounds 1, 2 and 3 (each within the scatter of the next, the first and the last beyond it).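

In this assay, bromo in place of chloro on an aromatic carbon, para to a large group, gives a number 8 percentage points higher from compound 2 to compound 3 (within the scatter) and supplies the first step recorded at this position. The 4-chlorophenyl and 4-bromophenyl compounds are therefore not told apart, and this position carries either halogen with no step beyond the scatter of the read-out. No supporting measurement is available to explain this step.

A fluoro, methoxy, amine or carboxylic acid group at this position lies outside the compounds shown, so it remains open whether any replacement here moves the paw edema read-out beyond the scatter. A single pair also leaves open whether the same exchange would give a similar step with another part of the shared core changed.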